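The compounds below may be only part of what the source reports. "The series", "measured", "known", "first", "only" and "open" are said of these compounds alone.

Compound 1, `CSc1coc(C(=O)CCCCCCc2ccccc2)n1`, was tested in an assay on isolated protein for inhibition of Fatty-acid amide hydrolase 1 (Rattus norvegicus) (on this read-out lower numbers stand for stronger inhibition and higher numbers for weaker inhibition), where compound 1 gives 29 nM. Two close relatives were measured alongside it. Compound 2, `O=C(CCCCCCc1ccccc1)c1nc(-c2cccnc2)co1`, gives 18 nM in this assay, and compound 3, `O=C(CCCCCCc1ccccc1)c1nc(-c2ccccc2)co1`, gives 65 nM. Compound 1 thus holds the second highest number of the three: the step of a 1.6-fold lower number from compound 1 to compound 2 (0.21 log units; within the scatter) stays within the usual scatter, while the step of a 2.2-fold higher number from compound 1 to compound 3 (0.35 log units; beyond the scatter) goes modestly beyond it. Compound 4, `COc1coc(C(=O)CCCCCCc2ccccc2)n1`, has not yet been measured. The change from compound 1 is methoxy in place of methylsulfanyl on an aromatic carbon. The measured steps at this same aromatic carbon, pyridin-3-yl in place of methylsulfanyl and phenyl in place of methylsulfanyl, each replaced the small group with a ring and moved the number only modestly in either direction. Among the measured compounds shown here, no measured step swaps methylsulfanyl for methoxy, so the expectation rests on the small size of both groups. A step in this assay no larger than the scatter is expected, a 1.2-fold higher number from compound 1 to compound 4 (0.08 log units; within the scatter). Compound 4 is therefore estimated at 35 nM, within a range from 12 nM to 100 nM.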

Compound 4, inhibition constant: 740 nM
Compound 4: the middle estimate sits 21-fold (1.33 log units) below what was measured; the whole stated range lies below it.
By their numbers in this assay, from the lowest: compounds 2 and 1 (each within the scatter of the next); then compound 3; then compound 4.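

Among the compounds shown here, at this position, two groups that match in the computed counts need not behave alike in this assay: methylsulfanyl and methoxy each have 2 heavy atoms, 1 hydrogen-bond acceptor and no ring, yet exchanging one for the other gives the largest step so far (a 26-fold higher number from compound 1 to compound 4 (1.41 log units; beyond the scatter)). The methoxy compound also stands well apart from both ring-bearing relatives (an 11-fold higher number from compound 3 to compound 4 (1.06 log units; beyond the scatter); a 41-fold higher number from compound 2 to compound 4 (1.61 log units; beyond the scatter)), so among these four compounds, methoxy alone gives a number far from the rest. No information is available on why this exchange matters so much.

The compounds shown cannot tell whether this large step is particular to methoxy or also extends to an ethoxy or a hydroxyl group. Going by these compounds, how a simple methyl group or an amine on the same aromatic carbon would compare also remains open.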